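This account rests on a few compounds, and the source may have more. Where it says the series, first, only, none or still open, it means among the compounds named here.

Measured compounds:
compound 1, `Clc1ccc(-c2ccc3nc(Cl)nc(N[C@@H]4C[C@H]5CC[C@@H]4C5)c3c2)cc1` — 46%
compound 2, `Clc1nc(N[C@@H]2C[C@H]3CC[C@@H]2C3)c2cc(-c3ccc(Cl)c(Cl)c3)ccc2n1` — 69%

In an ADME assay (Homo sapiens) for metabolic stability (a higher number here means that more of the compound is left, a lower number that less of the compound is left), compound 1 gives 46%. In this assay, among the measured compounds shown here, compound 2 gives 69%, the higher of the two numbers, and the only step measured so far, a number 23 percentage points higher from compound 1 to compound 2 (beyond the scatter), is the one that separates them.

Compound 3, `Clc1cc(Cl)cc(-c2ccc3nc(Cl)nc(N[C@@H]4C[C@H]5CC[C@@H]4C5)c3c2)c1`, has not yet been measured. It differs from compound 2 in one place: 3,5-dichlorophenyl in place of 3,4-dichlorophenyl on an aromatic carbon. No chlorine is added or taken away; one of the two is moved within the dichlorophenyl group.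

For the measured compounds named here, the one measured step bears on this change only at a distance. It shows that adding a second chlorine to this phenyl group raised the number in this assay modestly, but it says nothing about what moving a chlorine from one position to another does. With a change that keeps both chlorines, the step from compound 2 to compound 3 is expected to be small, possibly within the scatter, with a slight lean downward, as a number 7 percentage points lower from compound 2 to compound 3 (within the scatter) expresses. Compound 3 is therefore estimated at 62%, with a range from 45% to 80%.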

Compound 3, percent of the compound remaining: 85%
Compound 3: middle estimate off by 23 percentage points, on the low side; the measured number lies above the stated range.
By their numbers in this assay, from the lowest: compound 1; then compound 2; then compound 3.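

Moving one chlorine on the phenyl group, with no atom added or taken away, is enough to change the result in this assay: 3,5-dichlorophenyl in place of 3,4-dichlorophenyl gives a number 16 percentage points higher from compound 2 to compound 3 (beyond the scatter). Among these compounds, then, the arrangement of the two chlorines matters and not only their number, something the earlier step from one chlorine to two could not show. Measured against the single chlorine of 4-chlorophenyl, the 3,5-dichlorophenyl group gives a number 39 percentage points higher from compound 1 to compound 3 (beyond the scatter), a large step, but nothing available here explains why the placement of a chlorine changes how much of the compound is left.

Every phenyl group shown carries only chlorine, so it remains open whether the same arrangement would give a similar result with another group in its place, such as methyl, methoxy or nitrile. The rest of the shared core is also the same throughout, which leaves open whether the gain in this assay would hold if, for example, a morpholine replaced the chlorine on the core.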